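This account rests on a few compounds, and the source may have more. Where it says the series, first, only, none or still open, it means among the compounds named here.

Measured in a physicochemical assay for solubility, read by spectrophotometry, in phosphate buffer, with a stated time of 2 h, at pH 7.4 (a lower number here means a less soluble compound, a higher number a more soluble compound), so far:

Compound 1 `COc1ccc2[nH]c(C(=O)N3CC(=O)N(Cc4ccccc4)[C@@H](COc4ccccc4)C3)cc2c1` gives 12200 nM
Compound 2 `COc1ccc2[nH]c(C(=O)N3CC(=O)N(Cc4ccccc4)[C@@H](CN4CCC5(CC4)CC5)C3)cc2c1` gives 28200 nM
Compound 3 `COc1ccc2[nH]c(C(=O)N3CC(=O)N(Cc4ccccc4)[C@@H](CN4CCCC4)C3)cc2c1` gives > 25000 nM as a limit

For compound 3 the reading > 25000 nM is a limit and not a number. The change to compound 4 `COc1ccc2[nH]c(C(=O)N3CC(=O)N(Cc4ccccc4)[C@@H](COC(C)(C)C)C3)cc2c1` is tert-butoxy in place of pyrrolidin-1-yl on a saturated chain carbon bound to a saturated ring carbon and puts tert-butoxy in place of pyrrolidin-1-yl on a saturated chain carbon bound to a saturated ring carbon. The closest guide is compound 1, which carries phenoxy at that place. Two steps lead upward from it, a 2.3-fold higher number from compound 1 to compound 2 (0.36 log units; beyond the scatter) and an at least 2.0-fold higher number from compound 1 to compound 3 (0.31 log units; beyond the scatter) and neither is large. Compound 4 is expected to fall back toward compound 1, a modest move to a lower number in this assay here. The expected step is an at least 1.7-fold lower number from compound 3 to compound 4 (0.25 log units; that floor lies within the scatter) as estimated. For compound 4 the estimate is 14000 nM with an expected range from 6000 nM to 28000 nM overall.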

Compound 4, solubility: 65500 nM
Beside the measured number, compound 4's estimate is 4.7-fold (0.67 log units) below it; the measured number lies above the stated range.
By their numbers in this assay, from the lowest: compound 1; then compound 2; then compound 4.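

In this assay, keeping the oxygen at this place and putting tert-butyl in place of phenyl gives a 5.4-fold higher number from compound 1 to compound 4 (0.73 log units; beyond the scatter), so the group on that oxygen alone moves the number. A nitrogen-linked ring at this place is also not needed for a high reading, as shown by a 2.3-fold higher number from compound 2 to compound 4 (0.37 log units; beyond the scatter). Compound 3 has a limit and not a number, so its step to compound 4 cannot be read: the limit of > 25000 nM in this assay, at which 1 of the 4 values shown sits.

The compounds shown leave open whether the step from phenyl to tert-butyl follows from losing the ring or from the branching. Cyclohexyl or isopropyl on the same oxygen would separate the two.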